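Triazole Aryl Swap: Methoxyphenyl Replaces Trifluoromethylphenyl

A few compounds are considered here, and "the series" means these few. Any claim that something is new, unique, unknown or untested is made for them only; others in the source may bear on it.

Of the compounds shown here, three sharing one core have been measured in a functional assay on HepG2 cells (Homo sapiens) for inhibition, read by MTT assay, with a stated time of 72 h; a higher number here means a weaker inhibitor, a lower number a stronger inhibitor. Compound 1 `CC(C)c1ccc(-n2cc(COc3cccc(NC(=O)Nc4ccc(Cl)c(C(F)(F)F)c4)c3)nn2)cc1` gives 2470 nM, compound 2 `O=C(Nc1cccc(OCc2cn(-c3cccc(I)c3)nn2)c1)Nc1ccc(Cl)c(C(F)(F)F)c1` gives 4780 nM, and compound 3 `O=C(Nc1cccc(OCc2cn(-c3ccc(C(F)(F)F)cc3)nn2)c1)Nc1ccc(Cl)c(C(F)(F)F)c1` gives 1800 nM, the lowest number of the three, although its gap to compound 1 lies within the scatter and only its step from compound 2 is beyond it. Compound 4 `COc1ccccc1-n1cc(COc2cccc(NC(=O)Nc3ccc(Cl)c(C(F)(F)F)c3)c2)nn1` differs from compound 3 by 2-methoxyphenyl in place of 4-(trifluoromethyl)phenyl on an aromatic nitrogen. All three measured steps vary the same aryl group on the aromatic nitrogen: a 1.9-fold higher number from compound 1 to compound 2 (0.29 log units; within the scatter) and a 1.4-fold lower number from compound 1 to compound 3 (0.14 log units; within the scatter) stay within the scatter, while a 2.7-fold lower number from compound 2 to compound 3 (0.42 log units; beyond the scatter) is modest. A similarly small step is therefore expected for compound 4, most likely toward a somewhat higher number, a 1.4-fold higher number from compound 3 to compound 4 (0.16 log units; within the scatter). Compound 4 is estimated at 2600 nM, between 1000 nM and 6500 nM.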

Compound 4, half-maximal inhibitory concentration: 11300 nM
For compound 4 the middle estimate is 4.3-fold (0.64 log units) below the measured one; measured number outside the range, above it.
By their numbers in this assay, from the lowest: compounds 3, 1 and 2 (each within the scatter of the next, the first and the last beyond it); then compound 4.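

In this assay, compound 4 has the highest number of the four, with every step to it beyond the scatter: a 6.3-fold higher number from compound 3 to compound 4 (0.80 log units; beyond the scatter), a 4.6-fold higher number from compound 1 to compound 4 (0.66 log units; beyond the scatter) and a 2.4-fold higher number from compound 2 to compound 4 (0.37 log units; beyond the scatter). The aryl group on this aromatic nitrogen can therefore weaken inhibition more than the earlier swaps showed, and 2-methoxyphenyl brings a hydrogen-bond acceptor where 4-(trifluoromethyl)phenyl has none. No evidence here accounts for the change.

The compounds shown do not separate the methoxy group from its place on the ring. From the compounds shown here alone, how an amine or a carboxylic acid on this aryl ring would behave also remains open.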